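The compounds below may be only part of what the source reports. "The series", "measured", "known", "first", "only" and "open" are said of these compounds alone.

Working notes on the series. Compound 1 `O=C(Nc1cc(Cl)cc(Cl)c1)c1cnc(Cl)nc1C(F)(F)F` gives 500 nM in an assay on Jurkat cells for inhibition of cyclic AMP-dependent transcription factor ATF-1 (Homo sapiens); on this read-out lower numbers stand for stronger inhibition and higher numbers for weaker inhibition. Among the compounds with values here, compound 2 `CN(C(=O)c1cnc(Cl)nc1C(F)(F)F)c1cc(Cl)cc(Cl)c1` gives 3000 nM in this assay, and the step of a 6.0-fold higher number from compound 1 to compound 2 (0.78 log units; beyond the scatter) is the only single-point change measured so far. Compound 3 `CCCCNC(=O)c1cc(NC(=O)c2cnc(Cl)nc2C(F)(F)F)cc(C(F)(F)F)c1` returns only a limit in this assay, namely > 10000 nM. Compound 3 is one of the values sitting at the limit of > 10000 nM in this assay, at which 1 of the 3 values shown sits. Compound 4 `O=C(OC1CCCCC1)c1cc(NC(=O)c2cnc(Cl)nc2C(F)(F)F)cc(C(F)(F)F)c1` differs from compound 3 by cyclohexyloxy in place of butylamino on a carbonyl carbon. Within the data shown here, no measured step touches a carbonyl carbon; the one step, a 6.0-fold higher number from compound 1 to compound 2 (0.78 log units; beyond the scatter), concerns an amide-type nitrogen and offers no guide here. Because compound 3 stands at the limit (the limit of > 10000 nM in this assay, at which 1 of the 3 values shown sits), no step beyond the scatter is expected, a step that the limit leaves unreadable from compound 3 to compound 4. Compound 4 is accordingly estimated at 12000 nM, within 3000 nM to 40000 nM, with a limit rather than a number quite likely.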

Compound 4, half-maximal inhibitory concentration: 1200 nM
For compound 4 the middle estimate is 10-fold (1.00 log units) above the measured one, outside the stated range (below it).
By their numbers in this assay, from the lowest: compound 1; then compound 4; then compound 2. At a limit, above all of these: compound 3.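

The carbonyl carbon is a position at which the read-out in this assay can move: cyclohexyloxy in place of butylamino gives an at least 8.3-fold lower number from compound 3 to compound 4 (0.92 log units; beyond the scatter) on this part of the series. Compound 4, with cyclohexyloxy, has a ring and an oxygen where compound 3 has a chain and a nitrogen, and this single step does not separate these differences. Compound 3 stands at a limit, not a number: the limit of > 10000 nM in this assay, at which 1 of the 4 values shown sits.

On these data alone, whether the oxygen or the ring matters more stays open. Butoxy or cyclohexylamino on the same carbonyl carbon would separate the two.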